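One Ring Swap on Two Cores, One Expected Value

The source may report more compounds than this note shows. Statements on the series, on what has been measured and on what is new or still open speak of the compounds shown alone.

Measured so far:
compound 1, `C=C(Br)C(=O)Nc1cccc(/C=C2\SC(=O)N(Cc3cccc(F)c3)C2=O)c1`, gives 590 nM in a functional assay on L1210 cells (Mus musculus) for cytotoxicity, read by cell counting, with a stated time of 2 days; on this read-out higher numbers stand for weaker inhibition and lower numbers for stronger inhibition.
compound 2, `C=C(Br)C(=O)Nc1cccc(/C=C2\SC(=O)N(Cc3ccc(Cl)cc3)C2=O)c1`, gives 940 nM.
compound 3, `Nc1ccc(/C=C2\SC(=O)N(Cc3cccc(F)c3)C2=O)cc1`, gives 100000 nM.

Compound 1 and compound 2 share a core and differ only by 4-chlorophenyl in place of 3-fluorophenyl on a saturated chain carbon bound to an amide-type nitrogen in a ring. That change made a 1.6-fold higher number from compound 1 to compound 2 (0.20 log units; within the scatter), so on this core it is close to no change at all. Compound 3 stands far apart: its number is well beyond the scatter from both compound 1 and compound 2. How the core of compound 3 differs from the core of compound 1 is not broken down here.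

Compound 4, `Nc1ccc(/C=C2\SC(=O)N(Cc3ccc(Cl)cc3)C2=O)cc1`, is not yet measured. It differs from compound 3 by 4-chlorophenyl in place of 3-fluorophenyl on a saturated chain carbon bound to an amide-type nitrogen in a ring, the same change seen between compound 1 and compound 2, at the same place. Because a 1.6-fold higher number from compound 1 to compound 2 (0.20 log units; within the scatter) was within the scatter, the step is expected to be small again, about no change at the digits printed from compound 3 to compound 4 (within the scatter), with the weak cytotoxicity of the core of compound 3 carried over. Compound 4 is therefore estimated at 100000 nM in this assay, with a likely range from 40000 nM to 250000 nM.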

Compound 4, half-maximal inhibitory concentration: 37000 nM
Compound 4: middle estimate off by 2.7-fold (0.43 log units), on the high side, and the stated range ends above it.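

Replacing 3-fluorophenyl with 4-chlorophenyl does not carry over as one fixed step in this assay: on the core of compound 3, the change gives a 2.7-fold lower number from compound 3 to compound 4 (0.43 log units; beyond the scatter). Set beside the earlier result, the same change has a different size on the two cores: the same change on two cores in this assay, a 1.6-fold higher number (0.20 log units; within the scatter) from compound 1 to compound 2 and a 2.7-fold lower number (0.43 log units; beyond the scatter) from compound 3 to compound 4, 4.3-fold (0.63 log units) apart, beyond the scatter of two such steps. This shows that, for these two pairs, a step read on one core cannot simply be copied to the other, but it does not show why the cores differ or predict the step on a third core.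

The compounds shown leave open whether the difference follows the change of halogen or the different place named in the two groups, a question that 3-chlorophenyl and 4-fluorophenyl would help to separate. They also leave open how a plain phenyl or a 4-methoxyphenyl group would behave on either core, and which of the differences between the two cores matters.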